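The source may hold more compounds than are shown below. What is called first, only, known or untested is meant among the compounds shown, and "the series" means these compounds.

Of the compounds shown here, two of one shared core have been measured. Compound 1 `N#Cc1cnc(NCc2cnccc2C(F)(F)F)cc1NC[C@H]1CC[C@@H](O)CC1` and compound 2 `N#Cc1cnc(NCc2cnccc2C(F)(F)F)cc1NC[C@H]1CC[C@H](O)CC1` have the same atoms and bonds and differ only in configuration as drawn, with both stereocentres inverted. In an assay on isolated protein for inhibition of protein kinase C theta type (Homo sapiens), read by TR-FRET, with a stated time of 2 h (a lower number here means a stronger inhibitor, a higher number a weaker inhibitor), compound 1 gives 58 nM, and compound 2 gives 50 nM. The step is a 1.2-fold lower number from compound 1 to compound 2 (0.06 log units; within the scatter), so the two numbers cannot be told apart; compound 2 merely holds the lowest of the two numbers, its nearest neighbour being compound 1.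

Compound 3 `N#Cc1cnc(NCc2cnccc2C(F)(F)F)cc1N[C@H]1CC[C@@H](C(N)=O)CC1` has not yet been measured. It differs from compound 2 in one place: 4-carbamoylcyclohexyl in place of (4-hydroxycyclohexyl)methyl on a nitrogen on an aromatic ring. Within the data shown here, the only measured step, the mirror-image pair (the fact that compounds 1 and 2 differ only in the configuration as drawn), leaves the atoms and bonds untouched, so it says nothing about exchanging one ring substituent for another or about shortening the link between the ring and the nitrogen. Among the measured compounds shown here, no measured step therefore bears on this change, and the direction of any shift in this assay cannot be read from the two numbers in hand.

In the absence of guidance, compound 3 is expected to stay within a broad band around compound 2, with an expected step of a 2.0-fold higher number from compound 2 to compound 3 (0.30 log units; within the scatter). The estimate for compound 3 is 100 nM, within 20 nM to 500 nM.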

Compound 3, half-maximal inhibitory concentration: 7 nM
Compound 3: middle estimate off by 14-fold (1.15 log units), on the high side; the measured number lies below the stated range.
By their numbers in this assay, from the lowest: compound 3; then compounds 2 and 1 (each within the scatter of the next).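

In this assay, this place on a nitrogen on an aromatic ring turns out to respond to the group it carries: 4-carbamoylcyclohexyl in place of (4-hydroxycyclohexyl)methyl gives a 7.1-fold lower number from compound 2 to compound 3 (0.85 log units; beyond the scatter) and an 8.3-fold lower number from compound 1 to compound 3 (0.92 log units; beyond the scatter), whereas the earlier pair could not be told apart. Compound 3 therefore holds the lowest number of the three, and its steps to both other compounds lie beyond the scatter. The two steps describe the same exchange of groups, and they can be read together for a plain reason: the fact that compounds 1 and 2 differ only in the configuration as drawn.

The exchange alters two things at once: the methyl link of the old group is gone, and a carbamoyl stands where the hydroxyl stood, so the compounds shown cannot say which of these carries the step, a question that 4-hydroxycyclohexyl or (4-carbamoylcyclohexyl)methyl on the same nitrogen would address. They also leave open whether the other configuration of the 4-carbamoylcyclohexyl group, or a carboxylic acid in place of the carbamoyl, would keep the number this low.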